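A Fluorine Added to the Anilino Ring

This account rests on a few compounds, and the source may have more. Where it says the series, first, only, none or still open, it means among the compounds named here.

The three compounds measured here share one core and differ only in the ring carried on the amine nitrogen. Compound 1 `O=C1C(Nc2ccccc2)=CC(=O)c2c1nc1n2[C@H]2OC[C@@H](O)[C@H]2OC1` carries a plain anilino group. In a functional assay on MCF7 cells (Homo sapiens) for inhibition, read by sulforhodamine B assay (on this read-out higher numbers stand for weaker inhibition and lower numbers for stronger inhibition), compound 1 stops at the limit of > 4000 nM, so no number is known for it. Compound 2 `COc1ccccc1NC1=CC(=O)c2nc3n(c2C1=O)[C@H]1OC[C@@H](O)[C@H]1OC3`, with a 2-methoxyphenyl group, likewise stops at the limit of > 4000 nM in this assay. Compound 3 `COc1ccc(NC2=CC(=O)c3nc4n(c3C2=O)[C@H]2OC[C@@H](O)[C@H]2OC4)cc1`, with a 4-methoxyphenyl group, gives 5420 nM in this assay. The step that the limit leaves unreadable from compound 2 to compound 3 cannot be sized because of the limit of > 4000 nM in this assay, at which 2 of the 3 values shown sit. Compound 4 `O=C1C(Nc2cccc(F)c2)=CC(=O)c2c1nc1n2[C@H]2OC[C@@H](O)[C@H]2OC1` is the compound still to be measured; it differs from compound 1 by fluoro in place of hydrogen on an aromatic carbon. For the measured compounds named here, no measured step adds a fluorine, and the methoxy step cannot be read, so nothing measured bears directly on it. None of the three measured compounds shows strong inhibition, and a single fluoro gives no ground to expect otherwise. The expected step is a step that the limit leaves unreadable from compound 1 to compound 4, a small one. Compound 4 is therefore estimated at 5000 nM, with a range from 2500 nM to 20000 nM.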

Compound 4, half-maximal inhibitory concentration: > 4000 nM
Compound 4 ended at the assay's limit (the forecaster's own chance of this, stated with the estimate: 55%); the middle value does not contradict the limit.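

Compound 1 and compound 4 both stop at a limit in this assay, so no size can be read for the step between them: the limit of > 4000 nM in this assay, at which 3 of the 4 values shown sit.

Going by these compounds, the true values of compound 1 and compound 4 remain open, and with them whether fluoro in place of hydrogen changes inhibition at all.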